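The compounds below may be only part of what the source reports. "The series", "measured", "known", "first", "only" and "open" are said of these compounds alone.

Of the compounds shown here, two built on one shared core have been measured. In an assay on cells for inhibition of Ectonucleotide pyrophosphatase/phosphodiesterase family member 1 (Homo sapiens), with a stated time of 60 min (a lower number here means a stronger inhibitor, a higher number a weaker inhibitor), compound 1 `COc1cc2nc(/C=C/c3cccnc3)nc(N3CCC(CCNS(N)(=O)=O)CC3)c2cc1OC` gives 58 nM, and compound 2 `COc1cc2nc(/C=C/c3ccccc3F)nc(N3CCC(CCNS(N)(=O)=O)CC3)c2cc1OC` gives 211 nM. Within the data shown here, compound 2 thus stands at the higher of the two numbers, and the only measured step, a 3.6-fold higher number from compound 1 to compound 2 (0.56 log units; beyond the scatter), separates it from compound 1. Compound 3 `COc1cc2nc(/C=C/c3cccc(F)c3)nc(N3CCC(CCNS(N)(=O)=O)CC3)c2cc1OC` differs from compound 2 in a single respect: 3-fluorophenyl in place of 2-fluorophenyl on a double-bonded chain carbon bound to a double-bonded chain carbon. Among the measured compounds shown here, no measured step concerns a change in where the fluorine sits on the phenyl; the one known step, a 3.6-fold higher number from compound 1 to compound 2 (0.56 log units; beyond the scatter), exchanges the whole aromatic ring and so bears on this change only loosely. The expected step is therefore a 1.3-fold lower number from compound 2 to compound 3 (0.12 log units; within the scatter), and it is not expected to reach beyond the scatter in either direction. In this assay compound 3 is estimated at 160 nM, with a range from 55 nM to 450 nM.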

Compound 3, inhibition constant: 3580 nM
Beside the measured number, compound 3's estimate is 22-fold (1.35 log units) below it; the measured number lies above the stated range.
By their numbers in this assay, from the lowest: compound 1; then compound 2; then compound 3.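

The fluorine's place on the phenyl ring proves decisive: with the same atoms joined differently, the change from 2-fluorophenyl to 3-fluorophenyl in this assay gives a 17-fold higher number from compound 2 to compound 3 (1.23 log units; beyond the scatter), a larger step than the exchange of the whole ring in a 3.6-fold higher number from compound 1 to compound 2 (0.56 log units; beyond the scatter). Set against pyridin-3-yl, the 3-fluorophenyl group gives a 62-fold higher number from compound 1 to compound 3 (1.79 log units; beyond the scatter), so among these three compounds, all separated by steps beyond the scatter, compound 1 is the strongest inhibitor and compound 3 the weakest. Nothing at hand explains why moving one fluorine changes the number so strongly.

As far as these compounds go, what an unsubstituted phenyl would give on this chain remains open. So does whether a chlorine or a methoxy group in place of the fluorine would show a similar gap between the two ring positions.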